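The compounds below may be only part of what the source reports. "The series", "measured", "known", "first", "only" and "open" are said of these compounds alone.

Series of two measured compounds. In an assay on BTI-TN-5B1-4 cells for inhibition of Amine oxidase [flavin-containing] B (Homo sapiens), read by fluorescence and Amplex Red, using microsomes, with a stated time of 30 min (on this read-out lower numbers stand for stronger inhibition and higher numbers for weaker inhibition), compound 1 `C#CCOc1ccccc1-c1cc(-c2ccccc2OCC#C)nc(N)n1` gives 11100 nM, and compound 2 `C#CCOc1ccc(-c2cc(-c3ccccc3OCC#C)nc(-c3ccccc3)n2)cc1` gives 14400 nM; compound 2 stands alongside compound 1, the two numbers within the scatter of each other, so no order between them is claimed. Compound 3 `C#CCOc1ccccc1-c1cc(-c2ccccc2OCC#C)nc(-c2ccccc2)n1` differs from compound 2 only by a group of 10 heavy atoms (9 carbon, 1 oxygen; one six-membered aromatic ring of carbon only) in place of a group of 10 heavy atoms (9 carbon, 1 oxygen; one six-membered aromatic ring of carbon only), on an aromatic carbon. Among the measured compounds shown here, no step between measured compounds bears on this change, and no step beyond the scatter is expected in this assay in either direction. Compound 3 is therefore estimated at 12000 nM, within 4000 nM to 40000 nM, which would mean an expected step of a 1.2-fold lower number from compound 2 to compound 3 (0.08 log units; within the scatter).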

Compound 3, half-maximal inhibitory concentration: 13800 nM
Beside the measured number, compound 3's estimate is 1.2-fold (0.06 log units) below it; measured number inside the range.
By their numbers in this assay, from the lowest: compounds 1, 3 and 2 (each within the scatter of the next).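

In this assay, the isomeric exchange of the 4-(propargyloxy)phenyl on the aromatic carbon gives a 1.0-fold lower number from compound 2 to compound 3 (0.02 log units; within the scatter), so the arrangement of these same atoms does not separate compound 2 from compound 3. Among the compounds shown here, the first direct reading of phenyl in place of amino gives a 1.2-fold higher number from compound 1 to compound 3 (0.09 log units; within the scatter), so that exchange also shows no difference here. No data bear on why either exchange leaves the numbers within the scatter. Going by these compounds, whether any group at these places moves the number beyond the scatter stays open. A dimethylamino group or carboxylic acid in place of amino, or a longer chain than propargyloxy, would test this.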